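This account rests on a few compounds, and the source may have more. Where it says the series, first, only, none or still open, it means among the compounds named here.

In a physicochemical assay for solubility, in phosphate buffer, measured as kinetic solubility, at pH 7.4, tested at 250 uM (a lower number here means a less soluble compound, a higher number a more soluble compound), compound 1 (`CCCCCCNc1ccc(C(=O)O)cc1S(=O)(=O)N(C)C`) gives 243000 nM and compound 2 (`CN(C)S(=O)(=O)c1cc(C(=O)O)ccc1NCCCC(F)(F)F`) gives 245000 nM, so the two values lie within the scatter of each other. Compound 3 (`COCCCCNc1ccc(C(=O)O)cc1S(=O)(=O)N(C)C`) has not yet been measured. It carries methoxymethyl in place of the trifluoromethyl of compound 2 on a saturated chain carbon, three bonds along the chain from a nitrogen on an aromatic ring: methoxymethyl in place of trifluoromethyl on a saturated chain carbon, three bonds along the chain from a nitrogen on an aromatic ring. Among the measured compounds shown here, only one measured step bears on this change, the exchange of propyl for trifluoromethyl at that same place, and it amounts to a 1.0-fold higher number from compound 1 to compound 2 (0.00 log units; within the scatter). With that single step as the guide, no change beyond the scatter is expected, and the estimated step is a 1.0-fold lower number from compound 2 to compound 3 (0.01 log units; within the scatter). Compound 3 is expected to give about 240000 nM, within an estimated range of 185000 nM to 260000 nM.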

Compound 3, solubility: 247000 nM
Compound 3: the middle estimate sits 1.0-fold (0.01 log units) below what was measured; the range from low to high includes it.
By their numbers in this assay, from the lowest: compounds 1, 2 and 3 (each within the scatter of the next).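

In this assay the step of a 1.0-fold higher number from compound 2 to compound 3 (0.00 log units; within the scatter) lies within the scatter, so this position has now carried both trifluoromethyl and methoxymethyl, the latter with one hydrogen-bond acceptor where the former has none, and the two readings do not separate. The step of a 1.0-fold higher number from compound 1 to compound 3 (0.01 log units; within the scatter) also lies within the scatter, which adds methoxy in place of ethyl on a saturated chain carbon, four bonds along the chain from a nitrogen on an aromatic ring, to the changes that leave the number unmoved. All three numbers also stand close to the concentration tested, so this assay may leave little room for a higher reading.

No other measurement here bears on why these numbers agree. Going by these compounds, whether an amine, a hydroxyl or a much shorter chain at this place would lower the number beyond the scatter remains open.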